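Swapping an aromatic ring for cyclopropyl on the tetrazole

The source may report more compounds than this note shows. Statements on the series, on what has been measured and on what is new or still open speak of the compounds shown alone.

Measured so far in an assay on HEK293 cells for activation of Kir3.1/Kir3.2 (Homo sapiens), read by thallium flux; on this read-out higher numbers stand for larger maximal responses and lower numbers for smaller maximal responses:
- compound 1, `Cc1cc(NC(=O)Cn2nnc(-c3ccc(Cl)c(Cl)c3)n2)n(C2CCCCC2)n1`, gives 84%
- compound 2, `Cc1cc(NC(=O)Cn2nnc(-c3ccc(F)c(F)c3)n2)n(C2CCCCC2)n1`, gives 93%
- compound 3, `Cc1cc(NC(=O)Cn2nnc(-c3cccc(F)n3)n2)n(C2CCCCC2)n1`, gives > 83%

The value of compound 3 is a limit of this assay and not a number (the limit of > 83% in this assay, at which 1 of the 3 values shown sits). Compound 3 therefore stands only as a lower bound, with nothing to say about how far above it the true maximal response lies. Between compound 1 and compound 2 the step is a number 9 percentage points higher from compound 1 to compound 2 (within the scatter). The steps to compound 3 are a step that the limit leaves unreadable from compound 1 to compound 3 and a step that the limit leaves unreadable from compound 2 to compound 3.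

Compound 4, `Cc1cc(NC(=O)Cn2nnc(C3CC3)n2)n(C2CCCCC2)n1`, differs from compound 3 in one place: cyclopropyl in place of 6-fluoropyridin-2-yl on an aromatic carbon. Among the compounds with values here, none of the measured steps involves this kind of change, since each of them only exchanges one six-membered aromatic ring for another; so no step bears directly on it, and the expectation rests on the narrow band in which the three measured values sit. For compound 4 the step of a number at least 8 percentage points lower from compound 3 to compound 4 (that floor lies within the scatter) is expected, with a wide range. Compound 4 is estimated at 75%, between 45% and 100%.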

Compound 4, largest response reached (Emax), in percent of the reference or control that the assay uses: > 68%
Compound 4: no number, only a limit (the forecaster's own chance of this, stated with the estimate: 25%); the middle value lies beyond the limit too.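

Compound 4 gives only a limit and not a number, so no new step can be read from compound 1, compound 2 or compound 3 to compound 4: the limit of > 68% in this assay, at which 1 of the 4 values shown sits.

The compounds shown leave open how far the true maximal responses of compound 3 and compound 4 lie beyond their limits, and so whether cyclopropyl in place of an aromatic ring changes the response at all.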